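The source may report more compounds than this note shows. Statements on the series, on what has been measured and on what is new or still open speak of the compounds shown alone.

Of the compounds shown here, two have so far been measured in a functional assay on EKVX cells (Homo sapiens) for cytotoxicity, read by sulforhodamine B assay, with a stated time of 48 h; on this read-out higher numbers stand for weaker inhibition of growth and lower numbers for stronger inhibition of growth. Compound 1 `ClCc1cccc(Cn2cnc3c(Cl)ncnc32)c1` gives 18600 nM in this assay. Compound 2 `ClCc1ccccc1Cn1cnc2ncnc(Cl)c21` gives 5370 nM in this assay. Compound 2 therefore stands at the lower of the two numbers, and its nearest neighbour is compound 1, whose value is higher by a margin beyond the usual scatter of repeated measurements.

Compound 3 `ClCc1ccccc1Cn1cnc2nc(Cl)nc(Cl)c21` has not yet been measured. It differs from compound 2 in one place: chloro in place of hydrogen on an aromatic carbon, that is, a chloro in place of hydrogen on an aromatic carbon of the shared core, between two ring nitrogen atoms. Among the compounds with values here, no measured pair shows the effect of this kind of change, so the direction of the step is open. The step expected in this assay is a 1.3-fold lower number from compound 2 to compound 3 (0.13 log units; within the scatter), taken to be small and close to the scatter. For compound 3 the estimated value in this assay is 4000 nM, in a range from 1500 nM to 12000 nM.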

Compound 3, concentration for 50% growth inhibition: 1730 nM
Compound 3: middle estimate off by 2.3-fold (0.36 log units), on the high side, within the range that was stated.
By their numbers in this assay, from the lowest: compound 3; then compound 2; then compound 1.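

Putting a chloro on this aromatic carbon of the shared core, between two ring nitrogen atoms, gives a 3.1-fold lower number from compound 2 to compound 3 (0.49 log units; beyond the scatter) in this assay. Within the data shown here, this is the first step here between compounds that differ in one place, and it shows that this carbon can take a substituent, with one added chlorine moving the read-out towards stronger inhibition of growth by more than the scatter. Nothing measured here explains this shift.

From the compounds shown here alone, with only chloro and hydrogen compared at this position, it remains open whether a different group, such as an amine or a methoxy group, would lower the number as well, keep it unchanged or raise it. Also open, going by these compounds, is whether the same chloro would give a similar step on the core of compound 1.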